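Dimethylamino for Hydroxy on a Weakly Inhibiting Core

A few compounds are considered here, and "the series" means these few. Any claim that something is new, unique, unknown or untested is made for them only; others in the source may bear on it.

Two compounds of this small set carry numbers. In a functional assay on L1210 cells (Mus musculus) for inhibition (a lower number here means a stronger inhibitor, a higher number a weaker inhibitor), compound 1 `O=c1[nH]c(=O)n(COCCO)cc1[N+](=O)[O-]` gives 447 ug/mL. Compound 2 `Nc1nc2c(nc(O)n2COCCO)c(=O)[nH]1` returns only a limit of the assay in this assay, > 500 ug/mL, which is the limit of > 500 ug/mL in this assay, at which 1 of the 2 values shown sits. Compound 2 thus stands at that limit with no number of its own. Compound 3 `CN(C)c1nc2c(=O)[nH]c(N)nc2n1COCCO` differs from compound 2 by dimethylamino in place of hydroxy on an aromatic carbon. Within the data shown here, no measured step between compounds is available, so the step of an at least 1.1-fold lower number from compound 2 to compound 3 (0.04 log units; that floor lies within the scatter) is expected to stay within the scatter, in no clear direction. Compound 3 is therefore estimated at 450 ug/mL, between 150 ug/mL and 1200 ug/mL.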

Compound 3, concentration for 50% inhibition: > 500 ug/mL
Compound 3: a limit, no number; the forecaster's own chance of this, stated with the estimate: 55%; middle value at least 1.1-fold (0.04 log units) away from the limit.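

Compound 2 and compound 3 both stand at a limit in this assay, so no step can be read between them: the limit of > 500 ug/mL in this assay, at which 2 of the 3 values shown sit. On these data alone, whether dimethylamino in place of hydroxy on an aromatic carbon changes inhibition at all remains open.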